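Swapping acetyl for methyl on a quinone's aromatic oxygen

The source may report more compounds than this note shows. Statements on the series, on what has been measured and on what is new or still open speak of the compounds shown alone.

Three related compounds have been tested in a functional assay on MCF7 cells (Homo sapiens) for cytotoxicity, read by XTT assay, with a stated time of 24 h; on this read-out lower numbers stand for stronger inhibition and higher numbers for weaker inhibition. Compound 1 `CCOc1cc(C)c(Cl)c2c1C(=O)C=CC2=O` gives 40000 nM in this assay. Compound 2 `CC(=O)Oc1cc(OC(C)=O)c2c(OC(C)=O)cc(C)c(Cl)c2c1OC(C)=O`, which carries four acetyl groups on oxygen, gives 51100 nM in this assay. Compound 3 `CC(=O)Oc1c(C)cc(Cl)c2c1C(=O)C=CC2=O` gives 18700 nM in this assay, the lowest of the three numbers, and its gaps to compound 1 and to compound 2 both lie beyond the usual scatter, so among these three compound 3 shows the strongest inhibition of cell growth.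

Compound 4 `COc1c(C)cc(Cl)c2c1C(=O)C=CC2=O` has not yet been measured in this assay. It differs from compound 3 in one place: methyl in place of acetyl on an oxygen on an aromatic ring. The acetyl group is replaced by a smaller methyl group on the same oxygen, and the rest of the shared core is unchanged.

Among the measured compounds shown here, no pair of measured compounds differing only in this way is available, so the size and direction of the step cannot be read from the data. Compound 4 is expected to give a number close to that of compound 3, with a modest shift toward weaker inhibition considered somewhat more likely than the reverse. The expected step from this change is a 1.3-fold higher number from compound 3 to compound 4 (0.13 log units; within the scatter), an estimate rather than a measurement. In this assay compound 4 is estimated at 25000 nM, with a likely range from 8000 nM to 80000 nM.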

Compound 4, half-maximal inhibitory concentration: 16200 nM
Beside the measured number, compound 4's estimate is 1.5-fold (0.19 log units) above it; the measured number falls inside the stated range.
By their numbers in this assay, from the lowest: compounds 4 and 3 (each within the scatter of the next); then compounds 1 and 2 (each within the scatter of the next).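

In this assay, among the compounds shown here, the change from acetoxy to methoxy on this aromatic oxygen gives a 1.2-fold lower number from compound 3 to compound 4 (0.06 log units; within the scatter) and this is the first direct step, as no earlier pair differed in only one place. At this position, then, the acetyl group with its carbonyl can give way to a single methyl without a shift in this read-out beyond the usual scatter. The carbonyl of the acetyl group is therefore not needed to keep the number where compound 3 has it, although no data shown here say why the two groups read alike.

As far as these compounds go, with only acetyl and methyl compared on this oxygen of the shared core, it remains open how far the position tolerates other groups, such as a free hydroxyl, a longer chain like propyl, or a chain ending in an amine or a carboxylic acid. From the compounds shown here alone, it also remains open whether compound 3 and compound 4 would still read alike in other cell lines or over a longer exposure.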